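The source may report more compounds than this note shows. Statements on the series, on what has been measured and on what is new or still open speak of the compounds shown alone.

Measured so far:
compound 1 `COc1cc2c(cc1OC)C(CC(=O)Nc1ccccc1)CC2` — 37.5%
compound 2 `COc1cc2c(cc1OC)C(CC(=O)Nc1ccc(C)cc1)CC2` — 32.8%

For the measured compounds named here, in a functional assay on the whole organism (strain Wistar) for inhibition, with Rattus norvegicus as the target, read by paw edema, with a stated time of 4 h, at a dose of 100 mg/kg (a lower number here means less inhibition, a higher number more inhibition at the dose given (going by the name of the read-out)), compound 2 gives 32.8% and compound 1 gives 37.5%; the only step, a number 4.7 percentage points lower from compound 1 to compound 2 (within the scatter), is within the scatter, so the two numbers stand level. Compound 3 `COc1ccccc1NC(=O)CC1CCc2cc(OC)c(OC)cc21` is not yet measured. Change from compound 2: 2-methoxyphenyl in place of 4-methylphenyl on an amide-type nitrogen. Going by the values given here, the one measured step, a number 4.7 percentage points lower from compound 1 to compound 2 (within the scatter), concerns a methyl group and bears only loosely on a methoxy group; it gives no ground for a step beyond the scatter. The step of a number 1.2 percentage points higher from compound 2 to compound 3 (within the scatter) is therefore expected to stay within the scatter. Compound 3 is estimated at 34%, range 20% to 48%.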

Compound 3, a percentage reported as inhibition, in the whole organism at one dose (the size of the read-out at that dose, not a potency): 23.4%
Beside the measured number, compound 3's estimate is 10.6 percentage points above it; low and high end bracket the measured number.
By their numbers in this assay, from the lowest: compounds 3, 2 and 1 (each within the scatter of the next, the first and the last beyond it).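

In this assay, for the compounds shown here, the 2-methoxyphenyl group on the amide-type nitrogen gives the only step beyond the scatter, a number 14.1 percentage points lower from compound 1 to compound 3 (beyond the scatter). The direct exchange for 4-methylphenyl, a number 9.4 percentage points lower from compound 2 to compound 3 (within the scatter), stays within the scatter, so compound 3 and compound 2 stand level. No measurement at hand bears on the origin of either step.

Open, from the compounds shown here alone, is whether an amine or a carboxylic acid on this aromatic ring would keep the inhibition of compound 1. Also open, going by these compounds, is whether an ethoxy group would follow the methoxy group of compound 3.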